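Methoxy in place of hydroxy on the hydrazone aryl ring

The compounds below may be only part of what the source reports. "The series", "measured", "known", "first", "only" and "open" are said of these compounds alone.

Measured compounds in a functional assay on the whole organism (strain Wistar) for inhibition, with Rattus norvegicus as the target, read by paw edema, with a stated time of 30 min, at a dose of 10 mg/kg by the intraperitoneal route; on this read-out lower numbers stand for less inhibition and higher numbers for more inhibition at the one dose given (going by the name of the read-out):
Compound 1 `O=C(N/N=C/c1ccccc1)c1cccnc1Nc1cccc(C(F)(F)F)c1`: 60.4%
Compound 2 `O=C(N/N=C/c1cccc(F)c1)c1cccnc1Nc1cccc(C(F)(F)F)c1`: 58.3%
Compound 3 `O=C(N/N=C/c1ccc(O)cc1)c1cccnc1Nc1cccc(C(F)(F)F)c1`: 59.3%

Compound 3 stands second of the three numbers, and both of its neighbours lie within the scatter of it: the step of a number 1.1 percentage points lower from compound 1 to compound 3 (within the scatter) and the step of a number 1 percentage points higher from compound 2 to compound 3 (within the scatter) are each small. The step of a number 2.1 percentage points lower from compound 1 to compound 2 (within the scatter) is small as well, so the three numbers form one cluster.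

Compound 4 `COc1ccc(/C=N/NC(=O)c2cccnc2Nc2cccc(C(F)(F)F)c2)cc1` is not yet measured. It differs from compound 3 by methyl in place of hydrogen on an oxygen on an aromatic ring.

Within the data shown here, the steps that bear on this change are those on the same aryl ring: hydroxy in place of hydrogen, a number 1.1 percentage points lower from compound 1 to compound 3 (within the scatter), and fluoro in place of hydrogen, a number 2.1 percentage points lower from compound 1 to compound 2 (within the scatter). Both are within the scatter, so substitution on that ring has so far left the read-out unmoved. A methyl on the oxygen is expected to behave alike, and the step of a number 0.3 percentage points lower from compound 3 to compound 4 (within the scatter) is therefore expected to be none beyond the scatter.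

Compound 4 is estimated at 59%, with a range from 50% to 68%.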

Compound 4, a percentage reported as inhibition, in the whole organism at one dose (the size of the read-out at that dose, not a potency): 50.4%
Estimate against measurement, compound 4: 8.6 percentage points above, and the stated range covers the measured number.
By their numbers in this assay, from the lowest: compounds 4, 2, 3 and 1 (each within the scatter of the next).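

In this assay, methyl in place of hydrogen on the oxygen gives a number 8.9 percentage points lower from compound 3 to compound 4 (within the scatter) and is thus not shown to alter the read-out at this position. Among these compounds, the comparison with the unsubstituted ring, a number 10 percentage points lower from compound 1 to compound 4 (within the scatter) as methoxy replaces hydrogen, and the exchange of 3-fluorophenyl for 4-methoxyphenyl, a number 7.9 percentage points lower from compound 2 to compound 4 (within the scatter) in this series, are also printed as within the scatter, so compound 4 joins the cluster even though these steps are larger than those among the earlier compounds. No measurement on hand bears on the origin of these numbers.

Still open, going by these compounds, is whether an amine or a carboxylic acid on this ring, or a longer chain such as ethoxy or propoxy on the oxygen, would produce a step beyond the scatter. The compounds shown also leave open whether the cluster would hold at other doses or times.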